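This account rests on a few compounds, and the source may have more. Where it says the series, first, only, none or still open, it means among the compounds named here.

Compound 2 `COc1ccc(-c2cc3ccc(OCCCn4cc(CNC(=O)CCCCC5CCSS5)nn4)cc3oc2=O)cc1` gives 57.6% in a functional assay on PC-12 cells (Rattus norvegicus) for cytotoxicity, read by MTT assay, with stated times of 3 h and 2 h, tested at 10 uM; a lower number here means a weaker effect, a higher number a stronger effect of the compound at the concentration tested; the other measured compound, compound 1 `O=C(CCCCC1CCSS1)NCc1cn(CCCOc2ccc3cc(C(=O)O)c(=O)oc3c2)nn1`, gives 59.9% in this assay, and the two numbers lie within the scatter of each other, so compound 2 stands on a par with compound 1 rather than apart from it. The step of a number 2.3 percentage points lower from compound 1 to compound 2 (within the scatter) is the only measured one, an exchange of carboxy for 4-methoxyphenyl on an aromatic carbon. Compound 3 `O=C(CCCCC1CCSS1)NCc1cn(CCCOc2ccc3cc(-c4ccc(Br)cc4)c(=O)oc3c2)nn1` has not been measured; it differs from compound 2 by bromo in place of methoxy on an aromatic carbon - read one bond further out, 4-methoxyphenyl to 4-bromophenyl. Within the data shown here, no measured step covers this exchange, and the one step known at this place stayed within the scatter, which gives no sign of movement there. The step expected is a number 0.4 percentage points higher from compound 2 to compound 3 (within the scatter), nothing beyond the scatter. The estimate for compound 3 is 58%, with a range from 47% to 69%.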

Compound 3, a percentage reported as activity, at one concentration (the size of the read-out at that concentration, not a potency): 63.3%
Beside the measured number, compound 3's estimate is 5.3 percentage points below it; the measured number falls inside the stated range.
By their numbers in this assay, from the lowest: compounds 2, 1 and 3 (each within the scatter of the next).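

In this assay, among these compounds, the step of a number 5.7 percentage points higher from compound 2 to compound 3 (within the scatter) is the first look at the outer end of the 4-substituted phenyl group, on the aromatic carbon para to a large group, and exchanging methoxy for bromo there gives no change beyond the scatter. The step of a number 3.4 percentage points higher from compound 1 to compound 3 (within the scatter) shows that a second aryl group, 4-bromophenyl, also stays within the scatter of the carboxy compound, so neither aryl group sets itself apart from carboxy at that place. Nothing at hand offers an explanation for these readings.

The compounds shown leave open whether an amine, a carboxylic acid or a longer chain on that phenyl ring would shift the read-out beyond the scatter. Each compound was read at a single concentration, and the numbers speak only of the size of the effect at that concentration.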